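Aryl Variation on the Shared Core: From Compound 3 to Compound 4

A few compounds are considered here, and "the series" means these few. Any claim that something is new, unique, unknown or untested is made for them only; others in the source may bear on it.

For the measured compounds named here, compound 3 `COc1ccccc1-c1cn2ccnc2c(-c2ccc3ncn(C4CCCCC4)c3c2)n1` is one of three compounds measured in a functional assay on LOX IMVI cells (Homo sapiens) for inhibition, read by sulforhodamine B assay, with a stated time of 48 h, tested at 10 uM (a lower number here means less inhibition, a higher number more inhibition at the concentration tested (going by the name of the read-out)), where compound 3 gives 5.13%. Its two companions differ from it only in the aryl group on the shared core: compound 1 `c1ccc2c(-c3cn4ccnc4c(-c4ccc5ncn(C6CCCCC6)c5c4)n3)cccc2c1` gives 7.43% and compound 2 `CC(=O)c1ccc(-c2cn3ccnc3c(-c3ccc4ncn(C5CCCCC5)c4c3)n2)cc1` gives 14.5%. Compound 3 stands lowest of these three numbers, but the step of a number 2.3 percentage points lower from compound 1 to compound 3 (within the scatter) and the step of a number 9.4 percentage points lower from compound 2 to compound 3 (within the scatter) both fall within the scatter, so no real separation among the three is shown.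

Compound 4 `FC(F)(F)c1cccc(-c2cn3ccnc3c(-c3ccc4ncn(C5CCCCC5)c4c3)n2)c1` has not yet been measured. It differs from compound 3 in one place: 3-(trifluoromethyl)phenyl in place of 2-methoxyphenyl on an aromatic carbon. Going by the values given here, the two measured steps that bear on this change are the ones reaching compound 3 from compound 1 and from compound 2, and neither lies beyond the scatter; no measured compound carries the entering group. On that basis no step beyond the scatter is expected for compound 4 in this assay, the expected step being a number 3.9 percentage points higher from compound 3 to compound 4 (within the scatter). Compound 4 is therefore estimated at 9%, within a range from 0% to 22%.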

Compound 4, a percentage reported as inhibition, at one concentration (the size of the read-out at that concentration, not a potency): 3.45%
Compound 4: the middle estimate sits 5.6 percentage points above what was measured, within the range that was stated.
By their numbers in this assay, from the lowest: compounds 4, 3, 1 and 2 (each within the scatter of the next, the first and the last beyond it).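

In this assay, for the compounds shown here, the 3-(trifluoromethyl)phenyl group yields the first step at this position that lies beyond the scatter (a number 11.1 percentage points lower from compound 2 to compound 4 (beyond the scatter)), a modest step that sets it apart from 4-acetylphenyl. Its other two steps (a number 1.7 percentage points lower from compound 3 to compound 4 (within the scatter) and a number 4 percentage points lower from compound 1 to compound 4 (within the scatter)) stay within the scatter, so it is not separated from 2-methoxyphenyl or naphthalen-1-yl. Going by these compounds alone, no measurement on hand accounts for the one step beyond the scatter.

4-acetylphenyl and 3-(trifluoromethyl)phenyl differ both in the group carried and in where it sits on the phenyl ring, and the compounds shown leave open which of the two matters. They also leave open what a phenyl ring carrying an amine or a carboxylic acid would give at this position.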